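The source may hold more compounds than are shown below. What is called first, only, known or untested is meant among the compounds shown, and "the series" means these compounds.

Measured compounds:
compound 1 `COc1cccc(CNCCCNc2ccnc3cc(Oc4ccccc4)ccc23)c1O`: 9.28
compound 2 `COc1cccc(CNCCCNc2ccnc3cc(Cc4ccc(F)cc4)ccc23)c1O`: 9.47
compound 3 `COc1cccc(CNCCCNc2ccnc3cc(-c4ccc(F)cc4)ccc23)c1O`: 9.47

In a physicochemical assay for acid dissociation, compound 1 gives 9.28, compound 2 gives 9.47 and compound 3 gives 9.47. Compound 3 stands level with compound 2 no change at the digits printed from compound 2 to compound 3 (within the scatter), and its distance from compound 1 a number 0.19 log units higher from compound 1 to compound 3 (within the scatter) also lies within the scatter. Compound 4 `COc1ccccc1Oc1ccc2c(NCCCNCc3cccc(OC)c3O)ccnc2c1` differs from compound 3 by 2-methoxyphenoxy in place of 4-fluorophenyl on an aromatic carbon. Among the measured compounds shown here, the steps that bear on this are a number 0.19 log units higher from compound 1 to compound 3 (within the scatter) and a number 0.19 log units higher from compound 1 to compound 2 (within the scatter), both within the scatter, so the exchange of groups at this carbon has so far shifted this assay by little. For compound 4 a step of a number 0.17 log units lower from compound 3 to compound 4 (within the scatter) is therefore expected, again within the scatter. Compound 4 is estimated at 9.3, with a range from 9 to 9.6.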

Compound 4, acid dissociation constant: 9.28
Compound 4: middle estimate off by 0.02 log units, on the high side, and the stated range covers the measured number.
By their numbers in this assay, from the lowest: compounds 1, 4, 2 and 3 (each within the scatter of the next).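

In this assay, the steps of a number 0.19 log units lower from compound 3 to compound 4 (within the scatter) and a number 0.19 log units lower from compound 2 to compound 4 (within the scatter) show that this aromatic carbon also tolerates 2-methoxyphenoxy, a group with hydrogen-bond acceptors, without a shift beyond the scatter. Methoxy in place of hydrogen on the phenoxy ring gives no change at the digits printed from compound 1 to compound 4 (within the scatter) and so adds nothing measurable to this reading. No evidence is available that would explain these results.

Going by these compounds, whether an amine or a carboxylic acid on this carbon would shift the number in this assay remains open, as does the effect of a longer chain in the part shared by all four compounds.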